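The compounds below may be only part of what the source reports. "The series", "measured", "known", "first", "only" and "open" are said of these compounds alone.

Series measured in a functional assay on A549 cells (Homo sapiens) for inhibition, read by sulforhodamine B assay, with a stated time of 72 h; on this read-out lower numbers stand for stronger inhibition and higher numbers for weaker inhibition:
- compound 1 `C#Cc1cccc(Nc2ncnc3cc(OCCCCn4ccnc4[N+](=O)[O-])c(OC)cc23)c1`: 2210 nM
- compound 2 `C#Cc1cccc(Nc2ncnc3cc(OCCCCCn4ccnc4[N+](=O)[O-])c(OC)cc23)c1`: 770 nM

Of these two, compound 2 holds the lower number, at 770 nM. Compound 3 `C#Cc1cccc(Nc2ncnc3cc(OCCOCCn4ccnc4[N+](=O)[O-])c(OC)cc23)c1` carries 2-(2-nitro-1H-imidazol-1-yl)ethoxy in place of 3-(2-nitro-1H-imidazol-1-yl)propyl, on a saturated chain carbon, two bonds along the chain from an oxygen on an aromatic ring: 2-(2-nitro-1H-imidazol-1-yl)ethoxy in place of 3-(2-nitro-1H-imidazol-1-yl)propyl on a saturated chain carbon, two bonds along the chain from an oxygen on an aromatic ring. Among the compounds with values here, the only measured step, a 2.9-fold lower number from compound 1 to compound 2 (0.46 log units; beyond the scatter), is modest and bears only indirectly, as no measured step involves such an exchange. A small rise in this assay is therefore expected, and the expected change, a 1.4-fold higher number from compound 2 to compound 3 (0.15 log units; within the scatter), stays within the scatter. For compound 3 the estimated value is 1100 nM, with an expected range of 450 nM to 2800 nM.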

Compound 3, half-maximal inhibitory concentration: 9770 nM
Compound 3: the middle estimate sits 8.9-fold (0.95 log units) below what was measured, outside the stated range (above it).
By their numbers in this assay, from the lowest: compound 2; then compound 1; then compound 3.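

In this assay, chain length alone does not set the number at this position: 2-(2-nitro-1H-imidazol-1-yl)ethoxy in place of 3-(2-nitro-1H-imidazol-1-yl)propyl gives a 13-fold higher number from compound 2 to compound 3 (1.10 log units; beyond the scatter), although both groups hold 11 heavy atoms. The same group also compares poorly with the shorter chain, with a 4.4-fold higher number from compound 1 to compound 3 (0.65 log units; beyond the scatter), so the gain seen on lengthening the chain does not carry over to this exchange. No evidence on the cause is available. Open, from the compounds shown here alone, is whether an amine at the same chain place behaves like the ether oxygen, and whether a longer chain extends the gain.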